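This account rests on a few compounds, and the source may have more. Where it says the series, first, only, none or still open, it means among the compounds named here.

Measured in a functional assay on HeLa cells (Homo sapiens) for inhibition, with a stated time of 48 h, tested at 50 uM; a higher number here means more inhibition of growth at the concentration tested, a lower number less inhibition of growth:
compound 1 `C=C[C@@](C)(/C=C/c1ccc(OC(=O)CCCC)cc1)CCC=C(C)C`: 23%
compound 2 `C=C[C@@](C)(/C=C/c1ccc(OC(=O)CCCCCCCCC)cc1)CCC=C(C)C`: 50%
compound 3 `C=C[C@@](C)(/C=C/c1ccc(OC(=O)CCCCCCCCCCCCCCC)cc1)CCC=C(C)C`: 51%

Compound 1 stands lowest of the three. Compound 4 `C=C[C@@](C)(/C=C/c1ccc(OC)cc1)CCC=C(C)C` departs from it by methyl in place of butylcarbonyl on an oxygen on an aromatic ring. The nearest evidence comes from lengthening the ester chain: a number 27 percentage points higher from compound 1 to compound 2 (beyond the scatter) and a number 28 percentage points higher from compound 1 to compound 3 (beyond the scatter) are modest steps, while a number 1 percentage points higher from compound 2 to compound 3 (within the scatter) stays within the scatter. None of these steps removes the carbonyl, so they guide only loosely. Given a number 27 percentage points higher from compound 1 to compound 2 (beyond the scatter), a small downward step for the shorter group, or none beyond the scatter, is expected in this assay. The estimated step is a number 6 percentage points lower from compound 1 to compound 4 (within the scatter). The estimate for compound 4 is 17%, expected within 3% to 35%.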

Compound 4, percent growth inhibition at one concentration: 43%
The estimate for compound 4 lay 26 percentage points below the measured number; measured number above the stated range.
By their numbers in this assay, from the lowest: compound 1; then compounds 4, 2 and 3 (each within the scatter of the next).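

In this assay, the oxygen on the aromatic ring does not need a carbonyl for growth inhibition: methyl in place of butylcarbonyl gives a number 20 percentage points higher from compound 1 to compound 4 (beyond the scatter). The group with the fewest carbons at this oxygen therefore does not give the lowest number, so the rise seen along the esters does not extend to this ether. Nothing available accounts for this step. On these data alone, it remains open whether a free hydroxyl, an ethyl or butyl ether, or an acetyl ester would behave like methyl or like butylcarbonyl.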